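Nitro for Fluoro on a Pyrazolopyridine Cytotoxicity Series

The source may report more compounds than this note shows. Statements on the series, on what has been measured and on what is new or still open speak of the compounds shown alone.

Measured so far:
compound 1, `COc1ccc(-c2c(C#N)c(-c3cccnc3)nc3c2c(-c2cccnc2)nn3-c2ccccc2)cc1`, 3.73 ug/mL
compound 2, `COc1ccc(-c2c(C#N)c(-c3ccc(F)cc3)nc3c2c(-c2cccnc2)nn3-c2ccccc2)cc1`, 3.43 ug/mL

Of the compounds shown here, two have been tested in a functional assay on HepG2 cells (Homo sapiens) for cytotoxicity, read by colorimetric assay; a higher number here means a weaker inhibitor, a lower number a stronger inhibitor. Compound 1 gives 3.73 ug/mL, and compound 2 gives 3.43 ug/mL. The step of a 1.1-fold lower number from compound 1 to compound 2 (0.04 log units; within the scatter) lies within the scatter, so compound 2 stands level with compound 1; neither can be called the stronger of the two on these numbers.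

The next compound, compound 3 `COc1ccc(-c2c(C#N)c(-c3ccc([N+](=O)[O-])cc3)nc3c2c(-c2cccnc2)nn3-c2ccccc2)cc1`, is not yet measured. It differs from compound 2 by nitro in place of fluoro on an aromatic carbon; cut one bond further out, the change reads 4-fluorophenyl to 4-nitrophenyl.

Among the measured compounds shown here, no measured step touches this exchange. For the measured compounds named here, the only step in hand, a 1.1-fold lower number from compound 1 to compound 2 (0.04 log units; within the scatter), swaps one ring for another at the same position and stays within the scatter, which gives no hint of a shift in either direction. The expectation for compound 3 therefore rests on a flat prior: a step of a 1.0-fold higher number from compound 2 to compound 3 (0.01 log units; within the scatter) is expected, with no direction beyond the scatter.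

Compound 3 is estimated at 3.5 ug/mL in this assay, within a range of 1.6 ug/mL to 7.5 ug/mL.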

Compound 3, half-maximal inhibitory concentration: 13.5 ug/mL
The estimate for compound 3 lay 3.9-fold (0.59 log units) below the measured number; the whole stated range lies below it.
By their numbers in this assay, from the lowest: compounds 2 and 1 (each within the scatter of the next); then compound 3.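

In this assay, the exchange of fluoro for nitro on the six-membered aromatic ring gives a step beyond the scatter (a 3.9-fold higher number from compound 2 to compound 3 (0.60 log units; beyond the scatter)), so this position, which had shown no clear movement between pyridin-3-yl and 4-fluorophenyl, does respond to what is attached there, and the response is toward a weaker inhibitor. The step to 4-nitrophenyl from pyridin-3-yl (a 3.6-fold higher number from compound 1 to compound 3 (0.56 log units; beyond the scatter)) is also beyond the scatter, which leaves compound 3 as the weakest of the three, while compound 1 and compound 2 remain level with each other. Nothing available here bears on what lies behind this shift.

The compounds shown leave open whether an amine, a carboxylic acid or a chloro group in the same place, para to a large group, would stay level with compound 2 or move the number as nitro does. They also leave open whether the step from fluoro to nitro would keep its size with other groups on the shared core, since this exchange is seen on a single background.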